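The source may report more compounds than this note shows. Statements on the series, on what has been measured and on what is new or still open speak of the compounds shown alone.

Compound 2 `O=C(OCCc1c(-c2ccccc2Cl)c2cc(Cl)ccc2[nH]c1=O)c1cccs1` is an ester whose carbonyl carbon carries a thiophen-2-yl group. In an ADME assay on HepG2 2.2.15 cells (Homo sapiens) for cytotoxicity (a higher number here means that more compound is tolerated, a lower number that less compound is tolerated), compound 2 gives > 1700000 nM, which is a limit of the assay rather than a number, as recorded in the limit of > 1700000 nM in this assay, at which 1 of the 2 values shown sits. Going by the values given here, the only measured step starts from compound 1 `CC(=O)OCCc1c(-c2ccccc2Cl)c2cc(Cl)ccc2[nH]c1=O`, which in this assay gives 27000 nM; the step of an at least 62-fold higher number from compound 1 to compound 2 (1.79 log units; beyond the scatter) shows that the group on this carbonyl carbon can move the reading a long way. Compound 3 `O=C(/C=C/c1cccc(C(F)(F)F)c1)OCCc1c(-c2ccccc2Cl)c2cc(Cl)ccc2[nH]c1=O` differs from compound 2 by 2-(3-(trifluoromethyl)phenyl)ethenyl in place of thiophen-2-yl on a carbonyl carbon. The step from compound 1 to compound 2 bears on this only loosely, since it changed the same place but to a different group, and whether 2-(3-(trifluoromethyl)phenyl)ethenyl is tolerated as well as thiophen-2-yl is not known. Compound 3 is expected to show a step of an at least 3.4-fold lower number from compound 2 to compound 3 (0.53 log units; beyond the scatter). Compound 3 is therefore estimated in this assay at 500000 nM, within 60000 nM to 1700000 nM.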

Compound 3, half-maximal cytotoxic concentration: > 1400000 nM
Compound 3 ended at the assay's limit (the forecaster's own chance of this, stated with the estimate: 35%); middle value at least 2.8-fold (0.44 log units) away from the limit.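

In this assay compound 3 gives > 1400000 nM, which is a limit of the assay and not a number. Replacing the methyl on the carbonyl carbon with 2-(3-(trifluoromethyl)phenyl)ethenyl gives an at least 51-fold higher number from compound 1 to compound 3 (1.71 log units; beyond the scatter), so a second group, with a six-membered aromatic ring of carbon only and a double bond in place of a five-membered ring holding sulfur, also stands far from the methyl ester. The steps between compound 2 and compound 3 cannot be read, as both values are limits, and neither group can be ranked against the other. As far as these compounds go, it remains open whether a small saturated chain such as ethyl would already give such a step, or whether a ring is needed. An amine or a carboxylic acid on the far end of the group is also untested among the compounds shown here.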